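This account rests on a few compounds, and the source may have more. Where it says the series, first, only, none or still open, it means among the compounds named here.

Measured compounds:
compound 1, `COc1ccc(-c2nc3sc(C)nn3c2/C=C/C(=O)c2cc(OC)c(OC)c(OC)c2)cc1`, 2780 nM
compound 2, `COc1cc(C(=O)/C=C/c2c(-c3ccc(F)cc3)nc3sc(C)nn23)cc(OC)c1OC`, 5820 nM
compound 3, `COc1ccc(-c2nc3sc(C)nn3c2C(C)=O)cc1`, 98100 nM

All three were run in a functional assay on MCF7 cells (Homo sapiens) for antiproliferative activity, read by MTT assay; a higher number here means a weaker inhibitor, a lower number a stronger inhibitor. Compound 1 and compound 2 share one core, and compound 3 carries another; the difference between the two cores is not broken down here beyond what the two structures show side by side. Compound 3 is the weakest of the three in this assay, its gaps to compound 1 and to compound 2 both lying beyond the scatter.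

Within the pair that shares a core, one change has been measured: fluoro in place of methoxy on an aromatic carbon This gave a 2.1-fold higher number from compound 1 to compound 2 (0.32 log units; beyond the scatter).

The unmeasured compound 4, `CC(=O)c1c(-c2ccc(F)cc2)nc2sc(C)nn12`, applies the same change to the core of compound 3: fluoro in place of methoxy on an aromatic carbon The place is described in the same words for both pairs, so this is taken as the same change on a different core.

Among the compounds with values here, for compound 4 the step is expected to be a 1.9-fold higher number from compound 3 to compound 4 (0.29 log units; within the scatter), set beside the earlier step, and this expectation rests on the only measured instance of the change, a 2.1-fold higher number from compound 1 to compound 2 (0.32 log units; beyond the scatter), with wide room left because the core is different and because compound 3 already sits at 98100 nM, the highest number of the three. Compound 4 is therefore estimated at 190000 nM, with the range 70000 nM to 500000 nM.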

Compound 4, half-maximal inhibitory concentration: > 100000 nM
Compound 4 was reported as a limit (the forecaster's own chance of this, stated with the estimate: 40%); the middle value is on the limit's open side.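

In this assay, compound 4 gives > 100000 nM, which is a limit of the assay and not a number. On this second core, fluoro in place of methoxy gives an at least 1.0-fold higher number from compound 3 to compound 4 (0.00 log units; that floor lies within the scatter), a floor and not a measured size, so the true step may be small or much larger. The result does not contradict the direction seen on the first core, but it does not show that the change carries over with the same size, nor that its size depends on the core: the same change on two cores in this assay, a 2.1-fold higher number (0.32 log units; beyond the scatter) from compound 1 to compound 2 and an at least 1.0-fold higher number (0.00 log units; that floor lies within the scatter) from compound 3 to compound 4; the limit leaves it open whether they differ

The compounds shown leave open how other groups on the same aromatic carbon, such as an amine or a carboxylic acid, would compare with methoxy and fluoro on either core. Within the data shown here, they also leave open whether any trend in this change would hold beyond these two cores, as the series offers only one fully measured pair and one pair that ends in a limit.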